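Extending the saturated chain from compound 3 to compound 4

This account rests on a few compounds, and the source may have more. Where it says the series, first, only, none or still open, it means among the compounds named here.

Compound 1 `C=C[C@@](C)(/C=C/c1ccc(OC(=O)CCCC)cc1)CCC=C(C)C`: 21%
Compound 2 `C=C[C@@](C)(/C=C/c1ccc(OC(=O)CCCCCCC)cc1)CCC=C(C)C`: 51%
Compound 3 `C=C[C@@](C)(/C=C/c1ccc(OC(=O)CCCCCCCCC)cc1)CCC=C(C)C`: 52%
Compound 4 `C=C[C@@](C)(/C=C/c1ccc(OC(=O)CCCCCCCCCCCCCCC)cc1)CCC=C(C)C`: not yet measured

In a functional assay on IMR-32 cells (Homo sapiens) for inhibition, with a stated time of 48 h, tested at 50 uM (a lower number here means less inhibition of growth, a higher number more inhibition of growth at the concentration tested), compound 3 gives 52%. That leaves it level with compound 2 within the scatter and clearly apart from compound 1.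

The structural change that leads to compound 4 is hexyl in place of hydrogen on a saturated chain carbon, nine bonds along the chain from a carbonyl carbon. It extends the same saturated chain that already varies among the three measured compounds, so all three measured steps bear on it. The first extension gave a number 30 percentage points higher from compound 1 to compound 2 (beyond the scatter). The larger extension gave a number 31 percentage points higher from compound 1 to compound 3 (beyond the scatter). The extension that links the two longer chains gave only a number 1 percentage points higher from compound 2 to compound 3 (within the scatter). Across these three compounds, then, the rise seen with the first extension does not carry on to the last one, and no measured compound goes against that reading.

Going by the values given here, no measured compound has a chain as long as that of compound 4, so any forecast is an extrapolation. A further gain is not expected, given a number 1 percentage points higher from compound 2 to compound 3 (within the scatter), and a fall is thought somewhat more likely than a rise. The expected change is a number 10 percentage points lower from compound 3 to compound 4 (within the scatter). For compound 4, the estimated value in this assay is 42%, with an expected range from 18% to 62%.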

Compound 4, percent growth inhibition at one concentration: 54%
The estimate for compound 4 lay 12 percentage points below the measured number; the range from low to high includes it.
By their numbers in this assay, from the lowest: compound 1; then compounds 2, 3 and 4 (each within the scatter of the next).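

Hexyl in place of hydrogen on a saturated chain carbon, nine bonds along the chain from a carbonyl carbon, leaves the reading in this assay level (a number 2 percentage points higher from compound 3 to compound 4 (within the scatter)), so this large addition to the chain neither raises nor lowers growth inhibition at the concentration tested. Going by these compounds alone, the level stretch now reaches further than the earlier compounds could show, with octyl at seven bonds along the chain giving a number 3 percentage points higher from compound 2 to compound 4 (within the scatter) and undecyl at four bonds giving a number 33 percentage points higher from compound 1 to compound 4 (beyond the scatter) and leaving compound 1 as the only one of the four that stands apart. Nothing available explains why the reading stays level as the chain grows.

The compounds shown leave open where between the chains of compound 1 and compound 2 the reading rises, and whether a still longer chain would keep it level. They also leave open what an amine or a carboxylic acid on the saturated chain, or a branched chain in its place, would do to growth inhibition in this assay at this position.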